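Adding a 2-Carboxyethyl Side Chain to a Glycine Amide

The compounds below may be only part of what the source reports. "The series", "measured", "known", "first", "only" and "open" are said of these compounds alone.

Measured compounds:
compound 1 `N=C(N)NCCC[C@H](NC(=O)CN(c1nc(Cl)nc2[nH]cnc12)C1CC1)C(=O)O` — 45.4%
compound 2 `O=C(O)CNC(=O)CN(c1nc(Cl)nc2[nH]cnc12)C1CC1` — 32.2%

In a functional assay on the whole organism (Tail, strain ICR) with Mus musculus as the target, in the tail flick test, with a stated time of 30 min, at a dose of 25 umol/kg by the oral route (on this read-out lower numbers stand for a weaker effect and higher numbers for a stronger effect at the one dose given), compound 1 gives 45.4%, while compound 2 gives 32.2%. Among the measured compounds shown here, compound 2 therefore stands lowest of the two numbers known so far; its only neighbour, compound 1, lies higher by a step beyond the scatter. Compound 3 `O=C(O)CC[C@H](NC(=O)CN(c1nc(Cl)nc2[nH]cnc12)C1CC1)C(=O)O` differs from compound 2 by 2-carboxyethyl in place of hydrogen on a saturated chain carbon bound to an amide-type nitrogen and a carbonyl carbon. For the measured compounds named here, the single measured step that touches this place is a number 13.2 percentage points lower from compound 1 to compound 2 (beyond the scatter), where losing a side chain at the same place lowered the read-out modestly. Read in reverse, putting a side chain back at that place would be expected to lift the number, but the entering 2-carboxyethyl is a different group from the one that left, so a smaller rise, possibly none beyond the scatter, is expected. The step of a number 6.8 percentage points higher from compound 2 to compound 3 (within the scatter) is the expected change. Compound 3 is estimated at 39%, with a range from 24% to 54%.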

Compound 3, a percentage reported as activity, at one dose (the size of the read-out at that dose, not a potency): 26.8%
Estimate against measurement, compound 3: 12.2 percentage points above; low and high end bracket the measured number.
By their numbers in this assay, from the lowest: compounds 3 and 2 (each within the scatter of the next); then compound 1.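

In this assay a side chain at this place does not by itself bring the read-out back: a number 5.4 percentage points lower from compound 2 to compound 3 (within the scatter), so 2-carboxyethyl on the saturated chain carbon bound to an amide-type nitrogen and a carbonyl carbon makes no difference that can be told from the hydrogen. What the side chain carries counts, since a number 18.6 percentage points lower from compound 1 to compound 3 (beyond the scatter), a gap that the nitrogen-bearing end of compound 1 opens against the acid-bearing chain of compound 3. No measurement here says why these two side chains part.

As far as these compounds go, it remains open whether a plain amine at the end of the chain would keep the read-out of compound 1. A shorter or longer chain ending in a carboxylic acid, or a simple methyl at this place, is also untested among the compounds shown.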